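This account rests on a few compounds, and the source may have more. Where it says the series, first, only, none or still open, it means among the compounds named here.

Compound 1 `NS(=O)(=O)CC(=O)NCCSc1nonc1/C(=N/O)Nc1cccc(Cl)c1` gives 21 nM in an assay for inhibition of Indoleamine 2,3-dioxygenase 1 (Homo sapiens), read by fluorescence, with a stated time of 1 h (on this read-out lower numbers stand for stronger inhibition and higher numbers for weaker inhibition), the lowest of the three numbers in hand. Compound 3 `CS(=N)(=O)CC(=O)NCCSc1nonc1/C(=N/O)Nc1ccc(F)c(Br)c1` gives 61 nM, and compound 2 `NS(=O)(=O)NCCSc1nonc1/C(=N/O)Nc1ccc(F)c(Br)c1` gives 130 nM. Within the data shown here, the only step between measured compounds, a 2.1-fold lower number from compound 2 to compound 3 (0.33 log units; beyond the scatter), concerns the chain on the amine nitrogen, not the six-membered aromatic ring. Compound 4 `NS(=O)(=O)CC(=O)NCCSc1nonc1/C(=N/O)Nc1cccc(Br)c1` differs from compound 1 by bromo in place of chloro on an aromatic carbon. Among the measured compounds shown here, no measured step addresses this exchange; compounds 2 and 3 carry bromo on their ring, but they differ from compound 1 in a second place too, so their values give no clean halogen comparison. One halogen for the next is therefore expected to move this assay little, within the scatter, as a 1.2-fold higher number from compound 1 to compound 4 (0.08 log units; within the scatter). Compound 4 is estimated at 25 nM, ranging from 10 nM to 60 nM.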

Compound 4, half-maximal inhibitory concentration: 30 nM
Estimate against measurement, compound 4: 1.2-fold (0.08 log units) below; measured number inside the range.
By their numbers in this assay, from the lowest: compounds 1 and 4 (each within the scatter of the next); then compound 3; then compound 2.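

In this assay the change from 3-chlorophenyl to 3-bromophenyl gives a 1.4-fold higher number from compound 1 to compound 4 (0.15 log units; within the scatter) and so supplies the clean halogen comparison that compound 2 and compound 3 could not. At this place, on an aromatic carbon meta to a large group, the two halogens cannot be told apart on this chain. No independent evidence bears on why they read alike. Still open, as far as these compounds go, is whether fluoro, methyl or plain hydrogen on that carbon would read the same, and whether this exchange would read alike with other chains on the amine nitrogen.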